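The source may hold more compounds than are shown below. What is called first, only, known or untested is meant among the compounds shown, and "the series" means these compounds.

Three compounds built on the shared core of compound 1 `O=C1O[C@@H](CO)CN1c1ccc(-n2cc(-c3ccccn3)cn2)c(F)c1` have been measured in a physicochemical assay for lipophilicity, read by HPLC, measured as octanol-water partition; a higher number here means a more lipophilic compound, a lower number a more polar compound. Compound 1 gives 1.67 and stands second highest of the three. Compound 2 `CCN1CCN(C[C@H]2CN(c3ccc(-n4cc(-c5ccccn5)cn4)c(F)c3)C(=O)O2)CC1` gives 2.19, and the step of a number 0.52 log units higher from compound 1 to compound 2 (beyond the scatter) lies beyond the scatter. Compound 3 `O=C1CCC(=O)N1C[C@H]1CN(c2ccc(-n3cc(-c4ccccn4)cn3)c(F)c2)C(=O)O1` gives 1.58, so that a number 0.09 log units lower from compound 1 to compound 3 (within the scatter) stays within the scatter, while the step of a number 0.61 log units lower from compound 2 to compound 3 (beyond the scatter) is again a modest one beyond it.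

Compound 4 `CCNC(=O)NC[C@H]1CN(c2ccc(-n3cc(-c4ccccn4)cn3)c(F)c2)C(=O)O1` has not yet been measured. It differs from compound 1 in one place: (ethylcarbamoyl)amino in place of hydroxy on a saturated chain carbon bound to a saturated ring carbon. For the measured compounds named here, no measured step puts this exact group in place of the hydroxy, so the two steps that start from compound 1 are the only guide. Exchanging the hydroxy for a larger group moved the number up modestly in a number 0.52 log units higher from compound 1 to compound 2 (beyond the scatter) and left it unchanged in a number 0.09 log units lower from compound 1 to compound 3 (within the scatter). The entering (ethylcarbamoyl)amino is closer in size to the 2,5-dioxopyrrolidin-1-yl of compound 3 than to the 4-ethylpiperazin-1-yl of compound 2, and it carries 2 hydrogen-bond donors, so the expected step of a number 0.13 log units higher from compound 1 to compound 4 (within the scatter) is small, within or near the scatter. Compound 4 is therefore estimated at 1.8, with a range from 1.4 to 2.2.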

Compound 4, partition coefficient: 2.45
Compound 4: middle estimate off by 0.65 log units, on the low side, outside the stated range (above it).
By their numbers in this assay, from the lowest: compounds 3 and 1 (each within the scatter of the next); then compounds 2 and 4 (each within the scatter of the next).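

In this assay, the step of a number 0.78 log units higher from compound 1 to compound 4 (beyond the scatter) shows that this position can carry an open-chain group with no ring and still give a clear rise, even though (ethylcarbamoyl)amino has more hydrogen-bond donors than the hydroxy it replaces. The step of a number 0.87 log units higher from compound 3 to compound 4 (beyond the scatter) shows that two larger groups on this saturated chain carbon can lie well apart, so replacing the hydroxy with something larger does not alone fix the result, while the step of a number 0.26 log units higher from compound 2 to compound 4 (within the scatter) leaves compound 4 and the ring-bearing compound 2 together. No measurement is available to explain why the number moves with these groups.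

The compounds shown leave open which part of (ethylcarbamoyl)amino matters, a question that acetylamino, with no second nitrogen, or (methylcarbamoyl)amino and (propylcarbamoyl)amino, with a shorter or longer chain at the end, could help to answer. They also leave open how a simple primary amine or a carboxylic acid on the same carbon would compare.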